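Weighing an ester swap on a small measured series

The compounds below may be only part of what the source reports. "The series", "measured", "known", "first", "only" and "open" are said of these compounds alone.

Measured in a functional assay (trachea, Rattus norvegicus, strain Wistar); on this read-out higher numbers stand for an effect only at larger amounts of compound and lower numbers for an effect already at smaller amounts:
- compound 1 `CCCOc1cc2ccc(=O)oc2cc1OCCC`: 89000 nM
- compound 2 `CCOC(=O)COc1cc2ccc(=O)oc2cc1OCC(=O)OCC`: "not determined" (no result reported)
- compound 3 `CCOc1ccc2c(C)cc(=O)oc2c1`: 80000 nM

Compound 3, at 80000 nM, lies within the usual scatter of compound 1, at 89000 nM, and compound 2 offers no number to compare. Compound 4 `CCOC(=O)COc1ccc2c(C)cc(=O)oc2c1` has not yet been measured. It differs from compound 3 by ethoxycarbonyl in place of methyl on a saturated chain carbon bound to an oxygen on an aromatic ring. Within the data shown here, no measured pair differs in just one place, so the evidence is thin. No step beyond the scatter is expected in this assay, in either direction. The estimated change is a 1.1-fold higher number from compound 3 to compound 4 (0.05 log units; within the scatter). Compound 4 is expected at 90000 nM, with an estimated range of 30000 nM to 250000 nM.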

Compound 4, half-maximal effective concentration: 200000 nM
Compound 4: middle estimate off by 2.2-fold (0.35 log units), on the low side; the range from low to high includes it.
By their numbers in this assay, from the lowest: compounds 3 and 1 (each within the scatter of the next); then compound 4.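

Among these compounds, putting ethoxycarbonyl in place of methyl on a saturated chain carbon bound to an oxygen on an aromatic ring gives a 2.5-fold higher number from compound 3 to compound 4 (0.40 log units; beyond the scatter) in this assay and is the first single-place change that can be read here. It shows that this position is sensitive to the swap, since more compound is now needed for the effect. Nothing measured here explains the step. As far as these compounds go, whether a carboxylic acid or an amine at this place would stay close to methyl or follow ethoxycarbonyl remains open. So does whether the same swap would give a similar step on a different core.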